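Swapping the triazole substituent on a urea antiproliferative series

A few compounds are considered here, and "the series" means these few. Any claim that something is new, unique, unknown or untested is made for them only; others in the source may bear on it.

Of the compounds shown here, three sharing one core have been measured in a functional assay on NCI-H460 cells (Homo sapiens) for antiproliferative activity, read by MTT assay, with a stated time of 72 h; on this read-out lower numbers stand for stronger inhibition and higher numbers for weaker inhibition. Compound 1 `CN(C)CCn1cnnc1-c1cc(Oc2ccc(NC(=O)Nc3ccc(Cl)c(C(F)(F)F)c3)cc2F)ccn1` gives 1150 nM, the lowest number of the three. Compound 2 `CN(C)CCn1cnnc1-c1cc(Oc2ccc(NC(=O)Nc3ccc(F)c(F)c3)cc2F)ccn1` gives 9050 nM, and compound 3 `CN(C)CCn1cnnc1-c1cc(Oc2ccc(NC(=O)Nc3ccc(Cl)cc3Cl)cc2F)ccn1` gives 4350 nM. The measured steps all concern the aryl group on the urea: a 7.9-fold higher number from compound 1 to compound 2 (0.90 log units; beyond the scatter), a 3.8-fold higher number from compound 1 to compound 3 (0.58 log units; beyond the scatter) and a 2.1-fold lower number from compound 2 to compound 3 (0.32 log units; beyond the scatter). Compound 1 therefore stands apart from the other two, with both gaps beyond the scatter.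

Compound 4 `O=C(Nc1ccc(Oc2ccnc(-c3nncn3C3CC3)c2)c(F)c1)Nc1ccc(Cl)c(C(F)(F)F)c1` keeps the urea and the aryl group of compound 1 unchanged and differs only at the other end: cyclopropyl in place of 2-(dimethylamino)ethyl on an aromatic nitrogen. Among the measured compounds shown here, none of the measured steps touches this position, so the data give no direct guide to the size or direction of the change. In this situation the expectation for compound 4 rests on the value of compound 1, 1150 nM, with a widened range to allow for an untested change. Compound 4 is estimated to give 1500 nM, within 400 nM to 6000 nM. The expected step, a 1.3-fold higher number from compound 1 to compound 4 (0.12 log units; within the scatter), is thus one that may well fall within the scatter, with no direction asserted.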

Compound 4, half-maximal inhibitory concentration: > 50000 nM
Compound 4: a limit, no number (the forecaster's own chance of this, stated with the estimate: 3%); at least 33-fold (1.52 log units) between middle value and limit.
By their numbers in this assay, from the lowest: compound 1; then compound 3; then compound 2. At a limit, above all of these: compound 4.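

Replacing 2-(dimethylamino)ethyl with cyclopropyl on the aromatic nitrogen gives an at least 43-fold higher number from compound 1 to compound 4 (1.63 log units; beyond the scatter), a larger step than the widest one among the aryl groups on the urea, which is a 7.9-fold higher number from compound 1 to compound 2 (0.90 log units; beyond the scatter). In this assay compound 4 gives a limit and not a number: the limit of > 50000 nM in this assay, at which 1 of the 4 values shown sits. Compounds 1, 2 and 3 all carry the same 2-(dimethylamino)ethyl group, so only compound 4 shows that this position, with the urea and its aryl group held constant, can weigh more heavily on the read-out than the aryl changes seen so far.

The compounds shown leave open which feature of the departing group matters, since this one change removes the dimethylamino group and the open chain together, and a plain ethyl group, a 2-hydroxyethyl chain or a longer chain ending in the same dimethylamino group on this nitrogen would help to separate the two. On these data alone, it also remains open whether cyclopropyl has the same effect alongside the 3,4-difluorophenyl or 2,4-dichlorophenyl groups on the urea.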